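Adding a Methyl to the Ring Nitrogen of Compound 1

The source may hold more compounds than are shown below. What is called first, only, known or untested is meant among the compounds shown, and "the series" means these compounds.

For the measured compounds named here, in a functional assay on the whole organism for agonist activity, with Mus musculus as the target (on this read-out higher numbers stand for an effect only at larger amounts of compound and lower numbers for an effect already at smaller amounts), compound 1 `O=C1NCCN1CC#CCn1ccnc1` gives 30 mg/kg and holds the higher of the two exact numbers so far. Compound 3 `CN(C)CC#CCN1CCNC1=O` gives 9.7 mg/kg with dimethylamino in place of 1H-imidazol-1-yl, a change that yields a 3.1-fold lower number from compound 1 to compound 3 (0.49 log units; beyond the scatter) on this read-out. Compound 2 `Cc1cncn1CC#CCN1CCNC1=O` reaches only a limit of the assay at > 100 mg/kg in this measurement. Going by the values given here, compound 4 `CN1CCN(CC#CCn2ccnc2)C1=O` carries methyl in place of hydrogen on an amide-type nitrogen in a ring as its one change, methyl in place of hydrogen on an amide-type nitrogen in a ring. Neither measured step alters that nitrogen, and only the methyl step of an at least 3.3-fold higher number from compound 1 to compound 2 (0.52 log units; beyond the scatter) offers a loose guide toward a higher number. A modest rise is expected, estimated as a 2.3-fold higher number from compound 1 to compound 4 (0.37 log units; beyond the scatter) for this change. Compound 4 is expected at 70 mg/kg with an estimated range of 20 mg/kg to 250 mg/kg around that figure.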

Compound 4, dose for half-maximal effect: 1.4 mg/kg
Estimate against measurement, compound 4: 50-fold (1.70 log units) above; measured number outside the range, below it.
By their numbers in this assay, from the lowest: compound 4; then compound 3; then compound 1. At a limit, above all of these: compound 2.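

In this assay, the amide-type nitrogen in the ring proves to be a place where a single added methyl counts heavily: a 21-fold lower number from compound 1 to compound 4 (1.33 log units; beyond the scatter), with no other change to the core. The same small group moved the number the other way when it stood on an aromatic carbon in compound 2, so the direction of the methyl effect depends on where it sits in these compounds. Nothing at hand accounts for the size of this step. From the compounds shown here alone, it remains open whether ethyl or a longer chain on this nitrogen would lower the number further. Also open, going by these compounds, is whether dimethylamino in place of 1H-imidazol-1-yl would add to the methyl step.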